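Carbonyl removal on the piperidine nitrogen: compound 2 to compound 3

This account rests on a few compounds, and the source may have more. Where it says the series, first, only, none or still open, it means among the compounds named here.

Compound 1 `CS(=O)(=O)c1cnc(O[C@H]2CC[C@H](OC3CCN(C(=O)Oc4ccccc4)CC3)CC2)cn1` gives 71.8 nM in a functional assay on isolated protein for agonist activity at Glucose-dependent insulinotropic receptor (Rattus norvegicus), read by HTRF and cAMP accumulation (a lower number here means that less compound is needed, a higher number that more compound is needed for the effect), and compound 2 `CS(=O)(=O)c1cnc(O[C@H]2CC[C@H](OC3CCN(C(=O)C4(C(F)(F)F)CCCC4)CC3)CC2)cn1` gives 108 nM; the step of a 1.5-fold higher number from compound 1 to compound 2 (0.18 log units; within the scatter) lies within the scatter, so the two numbers cannot be set apart. Compound 3 `CS(=O)(=O)c1cnc(O[C@H]2CC[C@H](OC3CCN(CC4(C(F)(F)F)CCCC4)CC3)CC2)cn1` differs from compound 2 by a group of 10 heavy atoms (7 carbon, 3 fluorine; one five-membered non-aromatic ring of carbon only) in place of a group of 11 heavy atoms (7 carbon, 1 oxygen, 3 fluorine; one five-membered non-aromatic ring of carbon only), on an amine nitrogen in a ring. Among the compounds with values here, no measured step changes this position, so the data give no guide to direction or size. Compound 3 is expected to give 200 nM (range 40 nM to 1500 nM), an estimated step of a 1.9-fold higher number from compound 2 to compound 3 (0.27 log units; within the scatter) with wide uncertainty.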

Compound 3, half-maximal effective concentration: 101 nM
Compound 3: the middle estimate sits 2.0-fold (0.30 log units) above what was measured; measured number inside the range.
By their numbers in this assay, from the lowest: compounds 1, 3 and 2 (each within the scatter of the next).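

In this assay, taking out the carbonyl on the amine nitrogen in a ring gives no change that can be read (a 1.1-fold lower number from compound 2 to compound 3 (0.03 log units; within the scatter)), so the hydrogen-bond acceptor counted in the leaving group is not needed at this position in this pair. Against the group of compound 1, the same holds (a 1.4-fold higher number from compound 1 to compound 3 (0.15 log units; within the scatter)), leaving all three groups on this nitrogen unresolved. No measured evidence bears on this result. Still open, as far as these compounds go, is whether a carboxylic acid, an amine or a longer chain on this nitrogen would move the number beyond the scatter.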